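Aryl-piperazine succinimide amides: trifluoromethyl step in seizure model

The compounds below may be only part of what the source reports. "The series", "measured", "known", "first", "only" and "open" are said of these compounds alone.

Measured compounds:
compound 1, `COc1cccc(N2CCN(C(=O)C(C)N3C(=O)CCC3=O)CC2)c1`: 0%
compound 2, `CCC(C(=O)N1CCN(c2ccccc2)CC1)N1C(=O)CCC1=O`: 0%

Both compounds were tested in a functional assay on the whole organism (strain Swiss) with Mus musculus as the target, in the maximal electroshock model, with a stated time of 2 h, at a dose of 100 mg/kg by the intraperitoneal route; a lower number here means a weaker effect, a higher number a stronger effect of the compound at the dose given. In this assay compound 1 gives 0%, and in this assay compound 2 gives 0%. Compound 2 stands level with compound 1 at the digits recorded; the two values fall within the usual scatter of each other, so nothing separates them and neither shows any protection at this dose and time.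

The next compound in the series is compound 3, `CCC(C(=O)N1CCN(c2cccc(C(F)(F)F)c2)CC1)N1C(=O)CCC1=O`. It differs from compound 2 in one place: trifluoromethyl in place of hydrogen on an aromatic carbon. Among the measured compounds shown here, no step between two measured compounds is available to show what a change of this kind does in this assay, so the expectation rests only on the flat picture given by compound 1 and compound 2.

Given that compound 2 gives 0%, the step from compound 2 to compound 3 is expected to be a number 10 percentage points higher from compound 2 to compound 3 (within the scatter), that is, no change beyond the scatter. For compound 3 in this assay the estimate is 10%, with a range from 0% to 40%.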

Compound 3, a percentage reported as activity, at one dose (the size of the read-out at that dose, not a potency): 0%
The estimate for compound 3 lay 10 percentage points above the measured number; measured number inside the range.
By their numbers in this assay, from the lowest: compounds 1, 2 and 3 (each within the scatter of the next).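

In this assay, among the compounds shown here, trifluoromethyl in place of hydrogen on an aromatic carbon, meta to a large group, gives no change at the digits printed from compound 2 to compound 3 (within the scatter), so this is the first direct reading of a change on the aromatic ring of the series, and at this place and this dose it does not lift the read-out. Since compound 2 already gives 0% and compound 3 gives 0%, the step starts from and ends at a read-out showing no protection, so it shows that the group does not confer protection here but cannot show whether it would weaken an effect. No independent measurement on these compounds bears on this result.

Still open, on these data alone, is whether an amine or a carboxylic acid at this same ring position, or a longer chain on the shared core, would give any protection in this assay. Equally open, as far as these compounds go, is whether compound 2 and compound 3 would separate at another dose or time, where the read-out could register a difference in either direction.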